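A few compounds are considered here, and "the series" means these few. Any claim that something is new, unique, unknown or untested is made for them only; others in the source may bear on it.

Notes on the series. For the measured compounds named here, in an ADME assay on S9 fraction from liver (Homo sapiens) for metabolic stability, tested at 0.1 uM (a higher number here means faster removal of the compound, a lower number slower removal), compound 1 `CCN(CC)c1cc(OCc2cc(F)c(Oc3ccc(Cl)c(C(F)(F)F)c3)c(F)c2)nc(=O)n1C` gives 9.87 mL/min/kg, the higher of the two numbers in hand, though the gap to its only neighbour is within the scatter. Compound 2 `Cn1c(N2CCCCC2)cc(OCc2cc(F)c(Oc3ccc(Cl)c(C(F)(F)F)c3)c(F)c2)nc1=O` gives 5.69 mL/min/kg in this assay, and the step between them, a 1.7-fold lower number from compound 1 to compound 2 (0.24 log units; within the scatter), does not separate the two compounds.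

Compound 3 `COC1CCN(c2cc(OCc3cc(F)c(Oc4ccc(Cl)c(C(F)(F)F)c4)c(F)c3)nc(=O)n2C)CC1` differs from compound 1 as follows: 4-methoxypiperidin-1-yl in place of diethylamino on an aromatic carbon.

Going by the values given here, only one measured step bears on this change, the one from compound 1 to compound 2, which also removes diethylamino for a six-membered non-aromatic ring on the same aromatic carbon and stays within the scatter. Among the compounds with values here, the added methoxy group has no counterpart among the measured compounds. A step no larger than the scatter is therefore expected in this assay for compound 3, with the direction left open. Compound 3 is estimated at 7.5 mL/min/kg, between 3.5 mL/min/kg and 16 mL/min/kg, which means an expected step of a 1.3-fold lower number from compound 1 to compound 3 (0.12 log units; within the scatter).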

Compound 3, clearance: 20.9 mL/min/kg
Compound 3: middle estimate off by 2.8-fold (0.45 log units), on the low side; measured number outside the range, above it.
By their numbers in this assay, from the lowest: compounds 2 and 1 (each within the scatter of the next); then compound 3.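

At this aromatic carbon, the amine can shift the number in this assay: the change gives a 2.1-fold higher number from compound 1 to compound 3 (0.33 log units; beyond the scatter), whereas the earlier swap to plain piperidin-1-yl stayed within the scatter. The comparison within the piperidine pair isolates the methoxy in place of hydrogen on a saturated ring carbon and gives a 3.7-fold higher number from compound 2 to compound 3 (0.57 log units; beyond the scatter), so in this pair the higher number goes with the added methoxy and not with the loss of diethylamino alone. Nothing measured here accounts for this rise.

On these data alone, whether the rise is specific to methoxy or would also appear with a hydroxy group or a fluorine on the same ring carbon remains open. As far as these compounds go, it is also open whether an oxygen inside the ring, as in morpholin-4-yl, would give a similar number.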